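Pendant aryl swaps on the imidazoline ether core

A few compounds are considered here, and "the series" means these few. Any claim that something is new, unique, unknown or untested is made for them only; others in the source may bear on it.

Compound 1 `c1ccc(-c2ccncc2)c(OCC2=NCCN2)c1` carries a pyridin-4-yl group on the shared core. In a functional assay for activation of Alpha-1D adrenergic receptor (Homo sapiens), read by calcium flux (a higher number here means that more compound is needed for the effect, a lower number that less compound is needed), compound 1 gives only a limit, < 100000 nM, not a number. Compound 2 `c1ccc(-c2ccsc2)c(OCC2=NCCN2)c1` bears thiophen-3-yl and in this assay compound 2 gives 12.6 nM. Compound 3 `c1ccc(-c2nccs2)c(OCC2=NCCN2)c1` bears 1,3-thiazol-2-yl and in this assay compound 3 gives 31.6 nM. Between the two measured numbers the step of a 2.5-fold higher number from compound 2 to compound 3 (0.40 log units; beyond the scatter) is modest. The steps a step that the limit leaves unreadable from compound 1 to compound 2 and a step that the limit leaves unreadable from compound 1 to compound 3 cannot be sized, because the limit of < 100000 nM in this assay, at which 1 of the 3 values shown sits, leaves compound 1 without a number.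

Compound 4 `Cc1ccc(-c2ccccc2OCC2=NCCN2)s1` differs from compound 1 by 5-methylthiophen-2-yl in place of pyridin-4-yl on an aromatic carbon. The two readable neighbours bearing five-membered sulfur-containing rings both give low numbers, so compound 4 is expected to land near them, with the step that the limit leaves unreadable from compound 1 to compound 4 itself unreadable in size for the same reason. The estimate for compound 4 in this assay is 20 nM, expected between 5 nM and 100 nM.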

Compound 4, half-maximal effective concentration: < 100000 nM
Compound 4 gave a limit, no number (the forecaster's own chance of this, stated with the estimate: 5%); the middle value lies beyond the limit too.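

In this assay compound 4 gives < 100000 nM, a limit and not a number. No new step to compound 4 from compound 1, compound 2 or compound 3 can be read: the limit of < 100000 nM in this assay, at which 2 of the 4 values shown sit.

The compounds shown leave open how far compound 1 and compound 4 stand from compound 2 and compound 3 in this assay.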